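Working notes: 4-methoxyphenyl to 4-nitrophenyl

A few compounds are considered here, and "the series" means these few. Any claim that something is new, unique, unknown or untested is made for them only; others in the source may bear on it.

- Compound 1 `N#C/C(=C\c1ccccc1OS(=O)(=O)c1ccc([N+](=O)[O-])cc1)C(=O)Nc1nnc(-c2cccs2)s1` gives 40% in this series
- Compound 2 `COc1ccc(S(=O)(=O)Oc2ccccc2/C=C(\C#N)C(=O)Nc2nnc(Cc3ccccc3)s2)cc1` gives 78% in this series

In a functional assay on RS4-11 cells (Homo sapiens) for inhibition, read by CCK-8 assay, with a stated time of 48 h, tested at 20 uM (on this read-out higher numbers stand for more inhibition of growth at the one concentration tested and lower numbers for less inhibition of growth), compound 2 is the higher of the two measured compounds, and the gap down to compound 1 lies beyond the scatter. Among the measured compounds shown here, these two compounds offer no comparison at a single position, so no measured step can serve as a direct guide.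

Compound 3 `N#C/C(=C\c1ccccc1OS(=O)(=O)c1ccc([N+](=O)[O-])cc1)C(=O)Nc1nnc(Cc2ccccc2)s1` arises from compound 2 through nitro in place of methoxy on an aromatic carbon on an aromatic carbon, para to a large group. For the measured compounds named here, the only evidence for 4-nitrophenyl is weak: compound 1 carries that group and gives 40% in this assay but is not otherwise matched to compound 3. A downward step is therefore expected, moderate in size and probably beyond the scatter. The estimated change a number 18 percentage points lower from compound 2 to compound 3 (beyond the scatter) reflects that expectation. Compound 3 is expected at 60% with an estimated range from 40% to 80% for this measurement.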

Compound 3, percent growth inhibition at one concentration: 57%
Beside the measured number, compound 3's estimate is 3 percentage points above it; low and high end bracket the measured number.
By their numbers in this assay, from the lowest: compound 1; then compound 3; then compound 2.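

In this assay, the change from 4-methoxyphenyl to 4-nitrophenyl now has its first matched reading: with the benzyl group held constant, nitro in place of methoxy gives a number 21 percentage points lower from compound 2 to compound 3 (beyond the scatter). With 4-nitrophenyl held constant, benzyl in place of thiophen-2-yl gives a number 17 percentage points higher from compound 1 to compound 3 (beyond the scatter), so each of the two places carries a step of its own, and both steps lie beyond the scatter. No accompanying data bear on the origin of either step.

On these data alone, each change rests on a single matched pair, so whether the nitro step has the same direction and size with thiophen-2-yl in place of benzyl remains open. Also open, as far as these compounds go, is how an amine or a carboxylic acid in place of methoxy on that aromatic carbon would read.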